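Fluorine on the acid ring of a weak modulator

This account rests on a few compounds, and the source may have more. Where it says the series, first, only, none or still open, it means among the compounds named here.

Measured so far:
compound 1 `COc1cc(C(=O)O)ccc1OCCCCOc1ccc(C(=O)CC(C)(C)C)c(O)c1C`: 109%
compound 2 `Cc1c(OCCCCOc2ccc(C(=O)O)cc2)ccc(C(=O)CC(C)C)c1O`: 51.9%
compound 3 `Cc1c(OCCCCOc2ccc(C(=O)O)cc2)ccc(C(=O)CC2CCCC2)c1O`: 26.7%

In an assay on HEK293 cells for positive allosteric modulation of metabotropic glutamate receptor 3 (Rattus norvegicus), read by thallium flux, with a stated time of 2.5 min (on this read-out lower numbers stand for smaller maximal responses and higher numbers for larger maximal responses), compound 3 gives 26.7%, the lowest of the three numbers, with compound 2 nearest at 51.9% and compound 1 furthest at 109%. Compound 4 `Cc1c(OCCCCOc2ccc(C(=O)O)cc2F)ccc(C(=O)CC2CCCC2)c1O` is not yet measured. It differs from compound 3 in one place: fluoro in place of hydrogen on an aromatic carbon.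

Going by the values given here, the only measured step, a number 25.2 percentage points lower from compound 2 to compound 3 (beyond the scatter), concerns a change at a saturated chain carbon bound to a carbonyl carbon, not at the aromatic ring, so no measured step speaks to a fluoro for hydrogen swap. With no comparable step shown, the expectation for compound 4 is a step of a number 1.3 percentage points higher from compound 3 to compound 4 (within the scatter), within the usual scatter. Compound 4 is therefore estimated at 28%, in the range 10% to 50%.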

Compound 4, largest response reached (reported as percent of maximum), in percent of the reference or control that the assay uses: 31.2%
The estimate for compound 4 lay 3.2 percentage points below the measured number; the measured number falls inside the stated range.
By their numbers in this assay, from the lowest: compounds 3 and 4 (each within the scatter of the next); then compound 2; then compound 1.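

In this assay, fluoro in place of hydrogen on an aromatic carbon, ortho to a large group and meta to a carboxy group, gives a number 4.5 percentage points higher from compound 3 to compound 4 (within the scatter), so compound 3 and compound 4 cannot be told apart on this read-out. A single fluorine at this place therefore does not lift the low maximal response of the cyclopentyl compound. Nothing shown explains this result.

As far as these compounds go, whether a larger group here, such as chloro or trifluoromethyl, would shift the response remains open. So does whether fluoro would act the same way on compound 2, which carries isopropyl instead of cyclopentyl.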